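The source may hold more compounds than are shown below. What is called first, only, known or untested is meant among the compounds shown, and "the series" means these compounds.

Compound 1 `CN1C(=O)N(c2ccccc2)C2NC(=S)N(/N=C/C=C/c3ccccc3)C21` and compound 2 `COc1ccccc1/C=C/C=N/N1C(=S)NC2C1N(C)C(=O)N2c1ccccc1` share one core and differ at a single aromatic carbon. In a functional assay on MCF7 cells (Homo sapiens) for inhibition, read by MTT assay, with a stated time of 72 h (a higher number here means a weaker inhibitor, a lower number a stronger inhibitor), compound 1 reaches only a limit of the assay, > 100000 nM. In this assay compound 2 gives 260 nM, the only true number shown. The other value, that of compound 1, is a limit (the limit of > 100000 nM in this assay, at which 1 of the 2 values shown sits). The step of an at least 380-fold lower number from compound 1 to compound 2 (2.58 log units; beyond the scatter) is large. Compound 3 `CCN1C(=O)N(c2ccccc2)C2NC(=S)N(/N=C/C=C/c3ccccc3OC)C21` differs from compound 2 in a different place: methyl in place of hydrogen on a saturated chain carbon bound to an amide-type nitrogen in a ring. Among the measured compounds shown here, no measured step touches this saturated chain carbon; the one large step concerns methoxy in place of hydrogen on an aromatic carbon and does not bear on this change. The step of a 1.2-fold higher number from compound 2 to compound 3 (0.06 log units; within the scatter) is therefore expected to be small, with no direction beyond the scatter. Compound 3 is estimated at 300 nM, with a range from 120 nM to 800 nM.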

Compound 3, half-maximal inhibitory concentration: 79100 nM
Compound 3: middle estimate off by 260-fold (2.42 log units), on the low side; measured number outside the range, above it.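

In this assay, methyl in place of hydrogen on a saturated chain carbon bound to an amide-type nitrogen in a ring, which turns methyl into ethyl, gives a 300-fold higher number from compound 2 to compound 3 (2.48 log units; beyond the scatter). Among the compounds shown here, this carbon, which no earlier step touched, is therefore a place where one added carbon moves the number far beyond the scatter, at least for this pair of compounds. Compound 1 remains the only compound at a limit rather than a true number: the limit of > 100000 nM in this assay, at which 1 of the 3 values shown sits.

With a single step at this place, the compounds shown do not reveal why one added carbon has so large an effect. They also leave open whether a longer chain such as propyl, or an ethyl chain carrying a hydroxyl group or an amine, would give a similar number.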